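Swapping the thiophene for a dimethoxyphenyl ketone

A few compounds are considered here, and "the series" means these few. Any claim that something is new, unique, unknown or untested is made for them only; others in the source may bear on it.

Three compounds that share one core have been run through a functional assay on Huh-7 cells (Homo sapiens) for inhibition, read by sulforhodamine B assay, with a stated time of 72 h; on this read-out higher numbers stand for weaker inhibition and lower numbers for stronger inhibition. Compound 1 `O=C(/C=C/c1cn(-c2ccccc2)nc1-c1cccnc1)c1ccsc1` carries a thiophen-3-yl on its carbonyl carbon, and in this assay compound 1 gives 1700 nM. Compound 2 `COc1cc(C(=O)/C=C/c2cn(-c3ccccc3)nc2-c2cccnc2)cc(OC)c1OC` and compound 3 `COc1ccc(C(=O)/C=C/c2cn(-c3ccccc3)nc2-c2cccnc2)c(OC)c1OC` carry methoxy-bearing benzene rings in the same place; in this assay compound 2 gives 1900 nM and compound 3 gives 2300 nM. Among the measured compounds shown here, all three numbers sit within the usual scatter of one another, so no single compound can be singled out as stronger or weaker than the rest.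

The next compound, compound 4 `COc1ccc(OC)c(C(=O)/C=C/c2cn(-c3ccccc3)nc2-c2cccnc2)c1`, differs from compound 1 in one spot: 2,5-dimethoxyphenyl in place of thiophen-3-yl on a carbonyl carbon. Since the benzene-ring ketones of compound 2 and compound 3 land so close to compound 1, the step is expected to stay within the scatter, with at most a slight drift toward a higher number. The step from compound 1 to compound 4 is therefore estimated at a 1.2-fold higher number from compound 1 to compound 4 (0.07 log units; within the scatter). For compound 4 the expected value is 2000 nM, with a likely range from 900 nM to 4500 nM.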

Compound 4, half-maximal inhibitory concentration: 1300 nM
Compound 4: middle estimate off by 1.5-fold (0.19 log units), on the high side, within the range that was stated.
By their numbers in this assay, from the lowest: compounds 4, 1, 2 and 3 (each within the scatter of the next).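

On this carbonyl carbon, the step to a ring with two methoxy groups and more heavy atoms is a 1.3-fold lower number from compound 1 to compound 4 (0.12 log units; within the scatter) in this assay. Thiophen-3-yl, a five-membered ring with sulfur, and 2,5-dimethoxyphenyl, a six-membered ring of carbon only with an extra hydrogen-bond acceptor, therefore cannot be told apart on this read-out, so this one exchange of ring size, ring atoms and substituents leaves the number within the scatter. Nothing measured here offers an explanation for this result.

Whether this position would accept any group equally remains open, as all the groups shown here are aromatic rings without charge or hydrogen-bond donors. A carboxylic acid or an amine on the ring attached to the carbonyl carbon could test that more sharply.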